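A Smaller Group in Place of Benzoyl: Half-Life Outlook

The source may report more compounds than this note shows. Statements on the series, on what has been measured and on what is new or still open speak of the compounds shown alone.

Three compounds have been measured in an ADME assay on the whole organism for pharmacokinetics, with Rattus norvegicus as the target; on this read-out higher numbers stand for a longer-lived compound and lower numbers for a shorter-lived compound:

Compound 1 `Cc1cc(C)c(NC(=O)c2sccc2S(=O)(=O)Nc2onc(C)c2Cl)c(Cl)c1`: 2.6 h
Compound 2 `Cc1cc(C)c(NC(=O)c2sccc2S(=O)(=O)Nc2onc(C)c2Cl)c(-c2ncco2)c1`: 5.3 h
Compound 3 `Cc1cc(C)c(NC(=O)c2sccc2S(=O)(=O)Nc2onc(C)c2Cl)c(C(=O)c2ccccc2)c1`: 3.95 h

Compound 3 stands second highest of the three numbers. Its nearest neighbour is compound 2, with a 1.3-fold lower number from compound 2 to compound 3 (0.13 log units; within the scatter); its furthest is compound 1, with a 1.5-fold higher number from compound 1 to compound 3 (0.18 log units; within the scatter). Going by the values given here, only the step between compound 1 and compound 2 lies beyond the scatter, a 2.0-fold higher number from compound 1 to compound 2 (0.31 log units; beyond the scatter).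

Compound 4 `C/C(=N\O)c1cc(C)cc(C)c1NC(=O)c1sccc1S(=O)(=O)Nc1onc(C)c1Cl` has not been measured. It differs from compound 3 at one place: a group of 4 heavy atoms (2 carbon, 1 nitrogen, 1 oxygen; no ring) in place of a group of 8 heavy atoms (7 carbon, 1 oxygen; one six-membered aromatic ring of carbon only), on an aromatic carbon. Both measured steps that end at compound 3 altered the same aromatic carbon, and both stayed within the scatter, so the record so far shows this position tolerating quite different groups with little movement in this assay. Among the compounds with values here, no measured step introduces the entering group, so there is nothing to point to a direction. Compound 4 is therefore expected to give a number close to that of compound 3, and the step of a 1.1-fold lower number from compound 3 to compound 4 (0.05 log units; within the scatter) is estimated to stay within the scatter. Compound 4 is estimated at 3.5 h, in the range 1.8 h to 7 h.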

Compound 4, half-life: 5.2 h
Estimate against measurement, compound 4: 1.5-fold (0.17 log units) below, and the stated range covers the measured number.
By their numbers in this assay, from the lowest: compounds 1, 3, 4 and 2 (each within the scatter of the next, the first and the last beyond it).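

The entering group has no ring and 1 hydrogen-bond donor, where benzoyl has a ring and 0 donors, yet in this assay the step reads a 1.3-fold higher number from compound 3 to compound 4 (0.12 log units; within the scatter). Going by these compounds alone, measured against the other two groups on this aromatic carbon, it gives a 1.0-fold lower number from compound 2 to compound 4 (0.01 log units; within the scatter) and a 2.0-fold higher number from compound 1 to compound 4 (0.30 log units; within the scatter), so all three new steps stay within the scatter, and compound 4 shows that an aromatic ring in this group is not needed for a number within the scatter of compound 2 and compound 3, although the step from compound 1 to compound 2 remains the one step here beyond the scatter. Nothing shown here accounts for these numbers.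

From the compounds shown here alone, whether the same holds for an acetyl group, which would keep the carbon-linked double bond without the hydrogen-bond donor, or for an amine or a carboxylic acid on this aromatic carbon, remains open. Also open, going by these compounds, is whether a longer chain in place of the entering group would stay within the scatter of compound 4 in this assay.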